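Aromatic methyl substitution on the hydroxamic acid isatin oxime series

The source may hold more compounds than are shown below. What is called first, only, known or untested is meant among the compounds shown, and "the series" means these compounds.

Compound 1 `O=C(CCCCCCN1C(=O)/C(=N\O)c2ccccc21)NO` is the unsubstituted parent of this small set. Within the data shown here, in a functional assay on NCI-H460 cells (Homo sapiens) for antiproliferative activity, read by sulforhodamine B assay, with a stated time of 48 h (a higher number here means a weaker inhibitor, a lower number a stronger inhibitor), compound 1 gives 890 nM, the lowest of the three numbers measured so far, though neither neighbour is separated from it beyond the scatter. Compound 2 `O=C(CCCCCCN1C(=O)/C(=N\O)c2cc(F)ccc21)NO` gives 1500 nM and compound 3 `O=C(CCCCCCN1C(=O)/C(=N\O)c2cc(Br)ccc21)NO` gives 970 nM. The two steps from the parent, a 1.7-fold higher number from compound 1 to compound 2 (0.23 log units; within the scatter) and a 1.1-fold higher number from compound 1 to compound 3 (0.04 log units; within the scatter), both stay within the scatter, as does a 1.5-fold lower number from compound 2 to compound 3 (0.19 log units; within the scatter).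

Compound 4 `Cc1ccc2c(c1)/C(=N/O)C(=O)N2CCCCCCC(=O)NO` has not yet been measured. It differs from compound 1 by methyl in place of hydrogen on an aromatic carbon; the new group sits on an aromatic carbon of a six-membered aromatic ring of carbon only within the shared core. Among the measured compounds shown here, the steps that bear on it are the two halogen-for-hydrogen replacements on an aromatic carbon, a 1.7-fold higher number from compound 1 to compound 2 (0.23 log units; within the scatter) and a 1.1-fold higher number from compound 1 to compound 3 (0.04 log units; within the scatter), neither of which moved the number beyond the scatter. On that basis the step from compound 1 to compound 4 in this assay is expected to be a 1.1-fold higher number from compound 1 to compound 4 (0.05 log units; within the scatter), that is, no change beyond the scatter in either direction. Compound 4 is therefore estimated at 1000 nM, with a range of 500 nM to 2000 nM.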

Compound 4, half-maximal inhibitory concentration: 2090 nM
For compound 4 the middle estimate is 2.1-fold (0.32 log units) below the measured one; the whole stated range lies below it.
By their numbers in this assay, from the lowest: compounds 1, 3, 2 and 4 (each within the scatter of the next, the first and the last beyond it).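

In this assay, methyl is the only one of the three replacements of hydrogen on this aromatic carbon to move the number beyond the scatter (a 2.3-fold higher number from compound 1 to compound 4 (0.37 log units; beyond the scatter)), a modest step that fluoro and bromo did not produce. The comparison with the bromo compound points the same way (a 2.2-fold higher number from compound 3 to compound 4 (0.33 log units; beyond the scatter)), so this carbon of the shared core does not tolerate every small group equally, although the step between the two single-atom-or-carbon extremes stays within the scatter (a 1.4-fold higher number from compound 2 to compound 4 (0.14 log units; within the scatter)) and leaves methyl and fluoro indistinguishable here. No measurement in hand accounts for the methyl step or for the difference between methyl and bromo.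

Going by these compounds, whether a methoxy group, an amine or a carboxylic acid on the same aromatic carbon would stay with compound 1 or go with compound 4 remains open, as does the behaviour of an ethyl group, which would show whether adding carbon continues the step. Also open, on these data alone, is whether methyl on another aromatic carbon of the shared core gives a step of this size, and whether the step survives with a shorter or longer chain carrying the hydroxamic acid.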